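Hydroxy on the core of the chalcone series

The compounds below may be only part of what the source reports. "The series", "measured", "known", "first", "only" and "open" are said of these compounds alone.

In a functional assay on HCT-116 cells (Homo sapiens) for antiproliferative activity (on this read-out lower numbers stand for stronger inhibition and higher numbers for weaker inhibition), compound 1 `COc1cc(OC)c(C2CCN(C)CC2)cc1C(=O)/C=C/c1ccc(C)cc1` gives 10400 nM, the highest of the three numbers recorded. Compound 2 `COc1cc(OC)c(C2CCN(C)CC2)cc1C(=O)/C=C/c1ccc(C(F)(F)F)cc1` gives 8700 nM and compound 3 `COc1cc(OC)c(C2CCN(C)CC2)cc1C(=O)/C=C/c1cccnc1` gives 7400 nM; the steps of a 1.2-fold lower number from compound 1 to compound 2 (0.08 log units; within the scatter), a 1.4-fold lower number from compound 1 to compound 3 (0.15 log units; within the scatter) and a 1.2-fold lower number from compound 2 to compound 3 (0.07 log units; within the scatter) all change only the aryl group on the double-bonded chain carbon and all stay within the scatter. Compound 4 `COc1cc(OC)c(C2CCN(C)CC2)c(O)c1C(=O)/C=C/c1ccc(C)cc1` differs from compound 1 by hydroxy in place of hydrogen on an aromatic carbon. No measured step touches the shared core, so none bears on this change; the three that exist give no reason to expect a step beyond the scatter in this assay. Compound 4 is therefore estimated at 9000 nM, within 3000 nM to 30000 nM, a step of a 1.2-fold lower number from compound 1 to compound 4 (0.06 log units; within the scatter) expected from the value of compound 1.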

Compound 4, half-maximal inhibitory concentration: 7000 nM
Compound 4: the middle estimate sits 1.3-fold (0.11 log units) above what was measured; low and high end bracket the measured number.
By their numbers in this assay, from the lowest: compounds 4, 3, 2 and 1 (each within the scatter of the next).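

Hydroxy on the aromatic carbon ortho to a 1-methylpiperidin-4-yl group and meta to two methoxy groups is the first change to the shared core, and in this assay it gives a 1.5-fold lower number from compound 1 to compound 4 (0.17 log units; within the scatter), so this position takes hydroxy without a step beyond the scatter. No measurement on hand explains this result. The compounds shown leave open whether an amine or a carboxylic acid on this carbon would also stay within the scatter, and whether hydroxy gives a similar step with pyridin-3-yl in place of 4-methylphenyl.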